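Amine Nitrogen Substituent and Maximal Response in the Series

This account rests on a few compounds, and the source may have more. Where it says the series, first, only, none or still open, it means among the compounds named here.

Within the data shown here, compound 1 `CCCS(=O)(=O)N1CC=C(c2ccc3c(c2)CC(C2CCN(Cc4ccccc4)CC2)O3)CC1` reaches 88% in a functional assay on HEK293 cells with Glucose-dependent insulinotropic receptor (Homo sapiens) as the target, read by cAMP accumulation, with a stated time of 60 min (a higher number here means a larger maximal response, a lower number a smaller maximal response), the higher of the two numbers measured so far; compound 2 `CCCS(=O)(=O)N1CC=C(c2ccc3c(c2)CC(C2CCN(C(=O)OC4CCCCC4)CC2)O3)CC1` reaches 56%. The step of a number 32 percentage points lower from compound 1 to compound 2 (beyond the scatter) went with cyclohexyloxycarbonyl in place of benzyl on an amine nitrogen in a ring. Compound 3 `CCCS(=O)(=O)N1CC=C(c2ccc3c(c2)CC(C2CCN(c4ncc(C5CC5)cn4)CC2)O3)CC1` differs from compound 1 by 5-cyclopropylpyrimidin-2-yl in place of benzyl on an amine nitrogen in a ring. Among the measured compounds shown here, only the step from compound 1 to compound 2 bears on this change, as it also removes the benzyl at the same place, and it was large and downward. A downward step is therefore expected in this assay, with wide uncertainty, as a number 18 percentage points lower from compound 1 to compound 3 (beyond the scatter). Compound 3 is estimated at 70%, with a range from 50% to 92%.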

Compound 3, largest response reached (Emax), in percent of the reference or control that the assay uses: 85%
Compound 3: the middle estimate sits 15 percentage points below what was measured; measured number inside the range.
By their numbers in this assay, from the lowest: compound 2; then compounds 3 and 1 (each within the scatter of the next).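

In this assay, 5-cyclopropylpyrimidin-2-yl in place of benzyl on the amine nitrogen gives a number 3 percentage points lower from compound 1 to compound 3 (within the scatter), so replacing benzyl at this place does not necessarily cost maximal response. Among these compounds, replacing cyclohexyloxycarbonyl with 5-cyclopropylpyrimidin-2-yl gives a number 29 percentage points higher from compound 2 to compound 3 (beyond the scatter), which leaves cyclohexyloxycarbonyl as the only one of the three groups tied to a step beyond the scatter. Nothing available explains this difference. Whether the cyclopropyl matters remains open, since a pyrimidin-2-yl without it is not among the compounds shown. Also open, from the compounds shown here alone, is how a simple acetyl or a longer alkyl chain on this nitrogen would behave.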